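Chloro for fluoro carried onto a second core

The source may report more compounds than this note shows. Statements on the series, on what has been measured and on what is new or still open speak of the compounds shown alone.

Compound 1 `COc1ccccc1S(=O)(=O)/C=C/c1ncccc1F` and compound 2 `COc1ccccc1S(=O)(=O)/C=C/c1ncccc1Cl` share one core and differ only by chloro in place of fluoro on an aromatic carbon. In an assay on U2OS cells for activation of nuclear factor erythroid 2-related factor 2 (Homo sapiens), read by chemiluminescence, with a stated time of 6 h (on this read-out higher numbers stand for an effect only at larger amounts of compound and lower numbers for an effect already at smaller amounts), compound 1 gives 877 nM, and compound 2 gives 142 nM, so that a 6.2-fold lower number from compound 1 to compound 2 (0.79 log units; beyond the scatter). Compound 3 `COc1ccc(S(=O)(=O)/C=C/c2ncccc2F)cc1` keeps the fluoro but sits on a second core; how the two cores differ is not broken down here. In this assay compound 3 gives 1080 nM, a number within the scatter of compound 1, so the move between cores on its own does not shift the read-out in a way that can be read. Compound 4 `COc1ccc(S(=O)(=O)/C=C/c2ncccc2Cl)cc1` is the untested partner of compound 3 and differs from it by chloro in place of fluoro on an aromatic carbon. The place of this exchange reads the same as in the first pair, so it is the same change made once more, seen so far in one pair only. Compound 4 is expected to repeat the earlier step, with a 5.7-fold lower number from compound 3 to compound 4 (0.75 log units; beyond the scatter), because compound 2 showed a 6.2-fold lower number from compound 1 to compound 2 (0.79 log units; beyond the scatter) against compound 1. Compound 4 is accordingly estimated at 190 nM, most likely between 70 nM and 500 nM.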

Compound 4, half-maximal effective concentration: 347 nM
The estimate for compound 4 lay 1.8-fold (0.26 log units) below the measured number; the range from low to high includes it.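

Chloro in place of fluoro on an aromatic carbon again lowers the number in this assay on the second core, giving a 3.1-fold lower number from compound 3 to compound 4 (0.49 log units; beyond the scatter), so the direction of the step is shared by the two pairs shown. The two steps cannot be told apart in size: the same change on two cores in this assay, a 6.2-fold lower number (0.79 log units; beyond the scatter) from compound 1 to compound 2 and a 3.1-fold lower number (0.49 log units; beyond the scatter) from compound 3 to compound 4, 2.0-fold (0.30 log units) apart, within the scatter of two such steps

Two pairs on two cores still do not make a rule for the whole series, and they show nothing about the reason for the lower numbers or about how the change reads in any other test.

From the compounds shown here alone, it remains open how bromo, methyl or nitrile would read at the same place, on a six-membered aromatic ring with 1 nitrogen, and whether any of them would go further than chloro. Going by these compounds, it is also open whether the chloro-for-fluoro step would persist on a core carrying an amine or a carboxylic acid in place of the methoxy group.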